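The compounds below may be only part of what the source reports. "The series", "measured", "known", "first", "only" and "open" are said of these compounds alone.

Compound 1 `Cc1ccccc1CNc1nn(-c2ccc(F)cc2F)cc1CNCCN1CCN(C)CC1` carries a (2-methylbenzyl)amino group on its core. In an ADME assay on Huh-7 cells (Homo sapiens) for cytotoxicity (on this read-out lower numbers stand for higher toxicity in this test and higher numbers for lower toxicity in this test), compound 1 gives > 20000 nM, which is a limit of the assay rather than a measured number. Compound 2 `Cc1ccccc1-c1nn(-c2ccc(F)cc2F)cc1CNCc1ccncc1` likewise reaches only a limit in this assay, > 20000 nM. Compound 3 `Cc1ccccc1-c1nn(-c2cccc(C(F)(F)F)c2)cc1CNCCN1CCN(C)CC1` gives a measured number in this assay, 18000 nM. Compound 1 therefore stands at the limit of > 20000 nM in this assay, at which 2 of the 3 values shown sit. Compound 4 `CN1CCN(CCNCc2cn(-c3ccc(F)cc3F)nc2C(C)(C)C)CC1` differs from compound 1 in one place: tert-butyl in place of (2-methylbenzyl)amino on an aromatic carbon. Within the data shown here, no pair of measured compounds differs in exactly this way, so no measured step shows what this change does. For compound 4 the expected step that the limit leaves unreadable from compound 1 to compound 4 stays within the scatter, in no clear direction. Compound 4 is estimated at 25000 nM, between 12000 nM and 60000 nM, and will quite possibly again be reported only as a limit.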

Compound 4, half-maximal cytotoxic concentration: > 20000 nM
Compound 4 ended at the assay's limit; the forecaster's own chance of this, stated with the estimate: 65%; the middle value is on the limit's open side.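

The step from compound 1 to compound 4 cannot be read, since both compounds reach only a limit in this assay: the limit of > 20000 nM in this assay, at which 3 of the 4 values shown sit.
The compounds shown leave open whether tert-butyl in place of (2-methylbenzyl)amino changes the result in this assay at all.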